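The source may hold more compounds than are shown below. What is called first, only, known or untested is meant among the compounds shown, and "the series" means these compounds.

Of the compounds shown here, three built on one shared core have been tested in a functional assay on MCF7 cells (Homo sapiens) for cytotoxicity, read by MTT assay, with a stated time of 72 h; a higher number here means a weaker inhibitor, a lower number a stronger inhibitor. Compound 1 `O=C1N/C(=N/c2csc(-c3ccc(Cl)cc3)c2)S/C1=C\c1ccccc1` carries an unsubstituted phenyl ring. In this assay compound 1 gives > 50000 nM, which is a limit of the assay rather than a number. Compound 2 `Cc1ccc(/C=C2\S/C(=N\c3csc(-c4ccc(Cl)cc4)c3)NC2=O)cc1` carries a methyl group on that ring and in this assay gives 900 nM. Compound 3 `CN(C)c1ccc(/C=C2\S/C(=N\c3csc(-c4ccc(Cl)cc4)c3)NC2=O)cc1` carries a dimethylamino group on that ring and in this assay gives 400 nM, the lowest of the two numbers measured. The steps of an at least 55-fold lower number from compound 1 to compound 2 (1.74 log units; beyond the scatter) and an at least 120-fold lower number from compound 1 to compound 3 (2.09 log units; beyond the scatter) are both large, while the step of a 2.3-fold lower number from compound 2 to compound 3 (0.35 log units; beyond the scatter) is modest. Compound 4 `O=C1N/C(=N/c2csc(-c3ccc(Cl)cc3)c2)S/C1=C\c1ccc(Br)cc1` changes the substituent once more: bromo in place of dimethylamino on an aromatic carbon. Going by the values given here, no measured step covers a bromo group, so the expectation leans on the fact that both methyl and dimethylamino gave numbers. Compound 4 is therefore expected to give a higher number than compound 3, an estimated step of a 6.3-fold higher number from compound 3 to compound 4 (0.80 log units; beyond the scatter). The estimate for compound 4 is 2500 nM, with a range from 600 nM to 20000 nM.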

Compound 4, half-maximal inhibitory concentration: 2500 nM
Compound 4: the middle estimate sits on the measured number at the digits printed; measured number inside the range.
By their numbers in this assay, from the lowest: compound 3; then compound 2; then compound 4. At a limit, above all of these: compound 1.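

Bromo at this place on the ring still brings a large gain in this assay, so the group that lowers the number need not be built on carbon and nitrogen: the change reads an at least 20-fold lower number from compound 1 to compound 4 (1.30 log units; beyond the scatter). The starting value for compound 1 is a limit of the assay and not a number: the limit of > 50000 nM in this assay, at which 1 of the 4 values shown sits. Among the substituted compounds, the choice of group also counts, as bromo is behind both of the others, with a 2.8-fold higher number from compound 2 to compound 4 (0.44 log units; beyond the scatter) and a 6.3-fold higher number from compound 3 to compound 4 (0.80 log units; beyond the scatter), so the presence of a group alone does not set the number.

From the compounds shown here alone, whether chloro, fluoro, methoxy or a carboxylic acid would land nearer to dimethylamino or to bromo remains open. Also open, going by these compounds, is how any of these groups would behave at another place on the ring.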